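Difluorophenyl in place of aminophenyl on the carbonyl carbon

The source may hold more compounds than are shown below. What is called first, only, known or untested is meant among the compounds shown, and "the series" means these compounds.

Compound 1 `COc1cc(-c2cc(/C=C/C(=O)c3ccc(N)cc3)[nH]n2)cc(OC)c1OC` was tested in a functional assay on T47D cells (Homo sapiens) for cytotoxicity, read by sulforhodamine B assay, with a stated time of 48 h, tested at 100 uM (a lower number here means a stronger effect, a higher number a weaker effect of the compound at the concentration tested), and gave -47%. Compound 2 `COc1ccc(-c2cc(/C=C/C(=O)c3ccc(N)cc3)[nH]n2)cc1OC` gave -40% in the same assay, and compound 3 `COc1ccc(-c2cc(/C=C/C(=O)c3cc(OC)c(OC)c(OC)c3)[nH]n2)cc1OC` gave -47%. The one single-point step among these three, a number 7 percentage points higher from compound 1 to compound 2 (within the scatter), lies within the scatter. Compound 1 thus stands level with compound 3 at the digits shown, the two together forming the lowest pair of the three numbers; compound 3 is its nearest neighbour, with no change at the digits shown, and compound 2 the furthest, still within the scatter.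

Compound 4 `COc1cc(-c2cc(/C=C/C(=O)c3ccc(F)c(F)c3)[nH]n2)cc(OC)c1OC` differs from compound 1 in one place: 3,4-difluorophenyl in place of 4-aminophenyl on a carbonyl carbon. Among the measured compounds shown here, no measured step touches this carbonyl-attached ring directly. The step from compound 1 to compound 2 concerns a methoxy on the other aromatic ring, and compounds 1 and 3, which do differ at the carbonyl-attached ring, show values that are level with each other. On this footing compound 4 is expected to stay close to compound 1, with an estimated step of a number 7 percentage points higher from compound 1 to compound 4 (within the scatter), no larger than the scatter. The expected read-out for compound 4 is -40%, in the range -70% to 0%.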

Compound 4, a percentage reported as activity, at one concentration (the size of the read-out at that concentration, not a potency): -11%
Compound 4: the middle estimate sits 29 percentage points below what was measured, and the stated range covers the measured number.
By their numbers in this assay, from the lowest: compounds 1, 3 and 2 (each within the scatter of the next); then compound 4.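

In this assay, the step of a number 36 percentage points higher from compound 1 to compound 4 (beyond the scatter) is the only one shown that lies beyond the scatter, and it falls on the group held by the carbonyl carbon, where 3,4-difluorophenyl replaces 4-aminophenyl. Among the compounds shown here, this position is therefore not indifferent to what it carries, whereas the one earlier single-place step, at a methoxy on the other aromatic ring, stayed within the scatter. The exchange also takes away the hydrogen-bond donor and acceptor counted for 4-aminophenyl and brings in two fluorines, but no measurement at hand says which part of this exchange accounts for the shift.

The compounds shown leave open whether losing the amine or gaining the fluorines matters more: an unsubstituted phenyl, a hydroxyphenyl or a dimethylaminophenyl on the same carbonyl carbon would help to separate the two. Also open, going by these compounds, is whether 3,4-difluorophenyl would bring a step of similar size in the setting of compound 2, which carries one methoxy fewer on the other aromatic ring.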